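Swapping cyclohexyl for benzyl on the shared core

This account rests on a few compounds, and the source may have more. Where it says the series, first, only, none or still open, it means among the compounds named here.

Of the compounds shown here, two with the same core have been tested in a functional assay on SK-MEL-5 cells (Homo sapiens) for inhibition, read by sulforhodamine B assay, with a stated time of 48 h, tested at 10 uM; on this read-out higher numbers stand for more inhibition at the one concentration tested (going by the name of the read-out) and lower numbers for less inhibition. Compound 1 `c1ccc2c(-c3cn4ccnc4c(-c4ccc5ncn(C6CCCCC6)c5c4)n3)cccc2c1` gives 4.06% in this assay. Compound 2 `COc1ccccc1-c1cn2ccnc2c(-c2ccc3ncn(C4CCCCC4)c3c2)n1` gives 8.94% in this assay, and the step of a number 4.9 percentage points higher from compound 1 to compound 2 (within the scatter) means the two numbers cannot be told apart; both stand for very little inhibition at the single concentration tested.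

The unmeasured compound 3 `c1ccc(Cn2cnc3ccc(-c4nc(-c5cccc6ccccc56)cn5ccnc45)cc32)cc1` differs from compound 1 in one place: benzyl in place of cyclohexyl on an aromatic nitrogen. Among the measured compounds shown here, the one measured step, from compound 1 to compound 2, concerns a different position on the core and a different kind of group, so no measured step bears directly on this change. With nothing to suggest a move in either direction, the expectation is that compound 3 stays near compound 1 in this assay, with a step no larger than the usual scatter. The estimated step is a number 1.9 percentage points higher from compound 1 to compound 3 (within the scatter), nothing beyond the scatter. Compound 3 is therefore expected to give about 6% in this assay, with a range from -8% to 22%.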

Compound 3, a percentage reported as inhibition, at one concentration (the size of the read-out at that concentration, not a potency): 9.69%
Compound 3: middle estimate off by 3.7 percentage points, on the low side; low and high end bracket the measured number.
By their numbers in this assay, from the lowest: compounds 1, 2 and 3 (each within the scatter of the next).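

Among the compounds shown here, on the aromatic nitrogen of the shared core, a change at this position can now be read for the first time: in this assay, benzyl in place of cyclohexyl gives a number 5.6 percentage points higher from compound 1 to compound 3 (within the scatter), so the two numbers cannot be told apart. Replacing a non-aromatic six-membered carbon ring with the benzyl group's aromatic one therefore leaves compound 3, like compound 1, with very little inhibition at the single concentration tested, and this pair gives no sign that either group matters more than the other here. No measurement on hand offers an explanation for how closely the two compounds read.

On these data alone, whether an amine, a carboxylic acid or a longer chain on this aromatic nitrogen would give a number clearly apart from these remains open, since cyclohexyl and benzyl are both hydrocarbon groups containing a six-membered ring. Also open, as far as these compounds go, is whether benzyl would read the same way on a core carrying 2-methoxyphenyl in place of naphthalen-1-yl.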